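Cytotoxicity notes: trifluoromethoxy to methyl on the pendant phenyl

A few compounds are considered here, and "the series" means these few. Any claim that something is new, unique, unknown or untested is made for them only; others in the source may bear on it.

Measured so far:
- compound 1, `FC(F)(F)Oc1ccc(-c2cc(COc3ccccc3-c3nc4ccccc4s3)on2)cc1`, 43900 nM in an ADME assay on MCF-10A cells (Homo sapiens) for cytotoxicity, read by MTT assay, with a stated time of 24 h; a higher number here means a weaker inhibitor, a lower number a stronger inhibitor
- compound 2, `FC(F)(F)c1cccc(-n2cc(COc3ccccc3-c3nc4ccccc4s3)nn2)c1`, 31100 nM in this assay

Both compounds share the same core carrying a benzothiazole-bearing aryl ether; they differ in the five-membered ring and in the group on the outer phenyl. Compound 1 gives the highest number of the two, and the nearest value, that of compound 2, sits within the usual scatter of repeated measurements, so the two compounds cannot be separated on these numbers. Among the compounds with values here, no step between measured compounds that differ in a single place is available, so nothing is known yet about how a change on the outer phenyl moves this read-out.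

Compound 3, `Cc1ccc(-c2cc(COc3ccccc3-c3nc4ccccc4s3)on2)cc1`, has not been measured. It differs from compound 1 as follows: methyl in place of trifluoromethoxy on an aromatic carbon. Within the data shown here, with no matched step to lean on, the expectation rests on the only two values in hand, which lie close together. The step from compound 1 to compound 3 is expected to be a 1.1-fold lower number from compound 1 to compound 3 (0.04 log units; within the scatter), that is, not beyond the scatter in either direction. For compound 3 the estimated value in this assay is 40000 nM, with a range from 15000 nM to 100000 nM.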

Compound 3, half-maximal inhibitory concentration: 26400 nM
Compound 3: middle estimate off by 1.5-fold (0.18 log units), on the high side; the measured number falls inside the stated range.
By their numbers in this assay, from the lowest: compounds 3, 2 and 1 (each within the scatter of the next).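

Within the data shown here, the first matched step on the outer phenyl, 4-(trifluoromethoxy)phenyl to 4-methylphenyl, gives a 1.7-fold lower number from compound 1 to compound 3 (0.22 log units; within the scatter) in this assay. At this place, on an aromatic carbon para to a large group, the read-out therefore does not separate trifluoromethoxy from methyl, although the leaving group has 5 heavy atoms and 1 hydrogen-bond acceptor and the entering group has 1 heavy atom and no hydrogen-bond acceptor. This rests on a single pair, and no measurement bearing on why the step has this size is at hand.

As far as these compounds go, it remains open whether a group of another kind at this place, such as an amine or a carboxylic acid, would give a step beyond the scatter in this assay. Also open, from the compounds shown here alone, is whether the exchange of trifluoromethoxy for methyl would give a step of similar size on the core of compound 2, which differs from compound 1 in more than one place and so cannot yet be set against this step.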